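The source may report more compounds than this note shows. Statements on the series, on what has been measured and on what is new or still open speak of the compounds shown alone.

Compound 3 `CS(=O)(=O)NCCNC(=O)CN1CN(c2ccccc2)C2(CCN(C(=O)c3ccc(C4CCCCC4)cc3)CC2)C1=O` is one of three close relatives built on the same core, differing only in the group on a carbonyl carbon. In an assay on HEK293 cells for displacement of a labelled ligand from NPC1-like intracellular cholesterol transporter 1 (Homo sapiens) (a higher number here means a weaker inhibitor, a lower number a stronger inhibitor), compound 3 gives 2100 nM, which places it second highest of the three numbers. Compound 2 `O=C(CN1CN(c2ccccc2)C2(CCN(C(=O)c3ccc(C4CCCCC4)cc3)CC2)C1=O)NCCO` gives 2000 nM, and compound 1 `CC1CCCN(C(=O)CN2CN(c3ccccc3)C3(CCN(C(=O)c4ccc(C5CCCCC5)cc4)CC3)C2=O)C1` gives 3600 nM; the gaps, a 1.1-fold higher number from compound 2 to compound 3 (0.02 log units; within the scatter) and a 1.7-fold lower number from compound 1 to compound 3 (0.23 log units; within the scatter), both stay within the scatter, as does a 1.8-fold lower number from compound 1 to compound 2 (0.26 log units; within the scatter). Compound 4 `O=C(CN1CN(c2ccccc2)C2(CCN(C(=O)c3ccc(C4CCCCC4)cc3)CC2)C1=O)NCO` is reached from compound 3 by hydroxy in place of (methanesulfonamido)methyl on a saturated chain carbon bound to an amide-type nitrogen. The step bearing most directly on this change is a 1.1-fold higher number from compound 2 to compound 3 (0.02 log units; within the scatter), which put methanesulfonamido in place of hydroxy without moving the number beyond the scatter, and the other two steps in this small series were likewise small. No change beyond the scatter is therefore expected, and the estimated step of a 1.0-fold higher number from compound 3 to compound 4 (0.02 log units; within the scatter) is close to flat. Compound 4 is expected to give about 2200 nM in this assay, with a likely range from 1000 nM to 4800 nM.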

Compound 4, half-maximal inhibitory concentration: 8300 nM
For compound 4 the middle estimate is 3.8-fold (0.58 log units) below the measured one; measured number outside the range, above it.
By their numbers in this assay, from the lowest: compounds 2, 3 and 1 (each within the scatter of the next); then compound 4.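

Among these compounds, with hydroxymethyl on the amide-type nitrogen, this position moves the number beyond the scatter in this assay for the first time: a 4.0-fold higher number from compound 3 to compound 4 (0.60 log units; beyond the scatter), and likewise a 4.2-fold higher number from compound 2 to compound 4 (0.62 log units; beyond the scatter). The end group on the 2-substituted ethyl chain had made no difference beyond the scatter, so this result shows that the position is not indifferent to every change, and that hydroxy in place of hydroxymethyl matters more than methanesulfonamido in place of hydroxy did. Compound 4 is also set apart from the 3-methylpiperidin-1-yl amide, a 2.3-fold higher number from compound 1 to compound 4 (0.36 log units; beyond the scatter), which makes it the weakest of the four. Nothing shown here explains this shift.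

A 3-hydroxypropyl chain on the same nitrogen would help show whether chain length or the hydroxymethyl group itself drives the change. On these data alone, how an aminomethyl group or a carboxylic acid on the chain would read also stays open.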